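The compounds below may be only part of what the source reports. "The series", "measured", "known", "first", "only" and "open" are said of these compounds alone.

Compound 1 `CCC(C)Oc1c(-c2cc(OC)c(OC)c(OC)c2)oc2ccccc2c1=O`: > 50000 nM, a limit
Compound 2 `CCCC(C)Oc1c(-c2cc(OC)c(OC)c(OC)c2)oc2ccccc2c1=O`: > 50000 nM, a limit
Compound 3 `CCN(CC)CCCCCOc1c(-c2cc(OC)c(OC)c(OC)c2)oc2ccccc2c1=O`: 33400 nM

Among the compounds with values here, in a functional assay on DU-145 cells (Homo sapiens) for antiproliferative activity, read by WST assay, with a stated time of 3 days (on this read-out lower numbers stand for stronger inhibition and higher numbers for weaker inhibition), compound 3 gives 33400 nM, the only actual number so far. Compound 1 and compound 2 both sit at the limit: the limit of > 50000 nM in this assay, at which 2 of the 3 values shown sit.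

Compound 4 `CCCCCN(CCCCC)CCCCOc1c(-c2cc(OC)c(OC)c(OC)c2)oc2ccccc2c1=O` carries dipentylamino in place of (diethylamino)methyl on a saturated chain carbon, four bonds along the chain from an oxygen on an aromatic ring.

Within the data shown here, two measured steps bear on this change: an at least 1.4-fold lower number from compound 1 to compound 3 (0.17 log units; that floor lies within the scatter) and an at least 1.4-fold lower number from compound 2 to compound 3 (0.17 log units; that floor lies within the scatter). Both floors lie within the scatter, and neither step swaps these two groups, so they offer only weak guidance. A modest move is expected, with wide uncertainty: a 2.2-fold lower number from compound 3 to compound 4 (0.35 log units; beyond the scatter). For compound 4 the estimated value in this assay is 15000 nM, with an expected range from 4000 nM to 50000 nM.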

Compound 4, half-maximal inhibitory concentration: 12500 nM
Compound 4: middle estimate off by 1.2-fold (0.08 log units), on the high side; the measured number falls inside the stated range.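

In this assay, dipentylamino in place of (diethylamino)methyl gives a 2.7-fold lower number from compound 3 to compound 4 (0.43 log units; beyond the scatter). Within the data shown here, this is the first step here that joins two actual numbers, so its size can be read, and it shows that changing the amine end of this chain can move the value with the core unchanged. The swap alters the groups on the nitrogen and the length of the linking chain together, so the data cannot credit either alone.

On these data alone, whether a ring amine such as piperidine, or a carboxylic acid, at this place would move the value further remains open. The comparison with the compounds lacking an amine stays loose: the limit of > 50000 nM in this assay, at which 2 of the 4 values shown sit.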